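Aryl substituent change on the shared core: cytotoxicity notes

This account rests on a few compounds, and the source may have more. Where it says the series, first, only, none or still open, it means among the compounds named here.

Compound 1 `O=c1[nH]c(Nc2cccc(F)c2)nc2cc(Cl)ccc12` — in an ADME assay on Vero cells (Chlorocebus sabaeus) for cytotoxicity, read by WST assay (a lower number here means that less compound is tolerated, a higher number that more compound is tolerated), compound 1 gives > 25000 nM, a limit.
Compound 2 `COc1cccc(Nc2nc3cc(Cl)ccc3c(=O)[nH]2)c1` — in this assay compound 2 gives > 25000 nM, also a limit.

Compound 2 thus stands at the limit of this assay. Among the measured compounds shown here, the one measured step, a step that the two limits leave unreadable from compound 1 to compound 2, cannot be read because both ends sit at the limit of > 25000 nM in this assay, at which 2 of the 2 values shown sit. Compound 3 `O=c1[nH]c(Nc2cccc(C(F)(F)F)c2)nc2cc(Cl)ccc12` differs from compound 2 by trifluoromethyl in place of methoxy on an aromatic carbon. For the measured compounds named here, no measured step bears on this change, so no step beyond the scatter is expected; the expected step of a number no higher from compound 2 to compound 3 (the limit leaves the size open) is flat. Compound 3 is expected at 25000 nM, with a range from 12000 nM to 50000 nM, most likely again reported only as a limit.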

Compound 3, half-maximal cytotoxic concentration: > 25000 nM
Compound 3 was reported as a limit; the forecaster's own chance of this, stated with the estimate: 80%; the middle value lies on the limit itself.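

No step to compound 3 from compound 1 or compound 2 can be read, since all three results are limits: the limit of > 25000 nM in this assay, at which 3 of the 3 values shown sit.

Open is whether fluoro, methoxy and trifluoromethyl differ at all in this assay, and at what concentration any of these compounds becomes cytotoxic.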